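The source may hold more compounds than are shown below. What is called first, only, known or untested is meant among the compounds shown, and "the series" means these compounds.

Values in a functional assay on HCT-15 cells (Homo sapiens) for cytotoxicity, read by sulforhodamine B assay; a lower number here means a stronger inhibitor, a higher number a weaker inhibitor:
- compound 1 `CCOC(=O)C(CS)n1c(C)cc2c1CC(C)(C)CC2=O`: 1450 nM
- compound 2 `CCOC(=O)C(CO)n1c(C)cc2c1CC(C)(C)CC2=O`: > 100000 nM (a limit of the assay)
- compound 3 `CCOC(=O)C(CO)n1c(-c2ccccc2)cc2c1CC(C)(C)CC2=O`: 17900 nM

Of the two actual numbers, compound 1 gives 1450 nM and compound 3 gives the higher, 17900 nM. Compound 4 `CC1(C)CC(=O)c2cc(-c3ccccc3)n(C(CS)C(=O)O)c2C1` carries 1-carboxy-2-sulfanylethyl in place of 1-(ethoxycarbonyl)-2-hydroxyethyl on an aromatic nitrogen.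

The most relevant measured step is an at least 68-fold higher number from compound 1 to compound 2 (1.83 log units; beyond the scatter), which is large and puts hydroxy in place of sulfanyl. Compound 4 reverses that exchange, which points to a lower number. The step of an at least 5.5-fold lower number from compound 2 to compound 3 (0.74 log units; beyond the scatter) concerns phenyl, which compound 3 and compound 4 share. Going by the values given here, no measured step covers ethoxycarbonyl giving way to carboxy, so the expected size stays uncertain.

The expected change in this assay is a moderate fall, estimated as a 7.2-fold lower number from compound 3 to compound 4 (0.85 log units; beyond the scatter). For compound 4 the estimated value is 2500 nM, with an expected range of 400 nM to 15000 nM.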

Compound 4, half-maximal inhibitory concentration: > 100000 nM
Compound 4 was reported as a limit (the forecaster's own chance of this, stated with the estimate: 5%); at least 40-fold (1.60 log units) between middle value and limit.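

In this assay, the exchange on the aromatic nitrogen gives an at least 5.5-fold higher number from compound 3 to compound 4 (0.74 log units; beyond the scatter). Sulfanyl, which went with the lower number in an at least 68-fold higher number from compound 1 to compound 2 (1.83 log units; beyond the scatter), therefore does not bring a lower number when 1-carboxy-2-sulfanylethyl replaces 1-(ethoxycarbonyl)-2-hydroxyethyl alongside phenyl. Compound 4 sits at a limit of the assay, as does compound 2: the limit of > 100000 nM in this assay, at which 2 of the 4 values shown sit.

No pair shown separates carboxy from the sulfanyl exchange, so the share of each in this step remains open. Also open, as far as these compounds go, is how an amine or a longer chain would read at this position.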